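The source may report more compounds than this note shows. Statements on the series, on what has been measured and on what is new or still open speak of the compounds shown alone.

Measured so far:
- compound 1 `COc1cccc(-c2cccc(NC(=O)C(Cl)Cl)c2)c1`: 4310 nM
- compound 2 `CC(C)c1ccc(-c2cc(NC(=O)C(Cl)Cl)cc(-c3ccc(C(C)C)cc3)c2)cc1`: 17400 nM
- compound 3 `CCOc1cccc(-c2cc(NC(=O)C(Cl)Cl)cc(-c3cccc(OCC)c3)c2)c1`: 8830 nM

All three were tested in a functional assay on A549 cells (Homo sapiens) for cytotoxicity, read by MTT assay, with a stated time of 68 h; on this read-out lower numbers stand for stronger inhibition and higher numbers for weaker inhibition. Compound 1 gives the lowest of the three numbers, at 4310 nM. Compound 3 gives 8830 nM, a higher number than compound 1 by a margin beyond the usual scatter, and compound 2 gives 17400 nM, higher still. Compound 1 is therefore the strongest inhibitor among the three.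

Compound 4 `O=C(Nc1cccc(-c2ccccc2)c1)C(Cl)Cl` has not yet been measured. It differs from compound 1 in one place: hydrogen in place of methoxy on an aromatic carbon. The shared core and the dichloroacetamide are unchanged; only the methoxy is gone. For the measured compounds named here, no measured pair here shows the effect of removing a single methoxy, so the expectation rests on compound 1 alone. Stripping a substituent from a weak series such as this is expected to give a modest loss in this assay, though a number within the scatter of compound 1 would not be surprising. Compound 4 is expected to give 6500 nM, with a likely range of 2200 nM to 19000 nM. That estimate corresponds to an expected step of a 1.5-fold higher number from compound 1 to compound 4 (0.18 log units; within the scatter).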

Compound 4, half-maximal inhibitory concentration: 8900 nM
Estimate against measurement, compound 4: 1.4-fold (0.14 log units) below, within the range that was stated.
By their numbers in this assay, from the lowest: compound 1; then compounds 3, 4 and 2 (each within the scatter of the next).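

For the compounds shown here, replacing the methoxy with hydrogen gives, in this assay, a 2.1-fold higher number from compound 1 to compound 4 (0.31 log units; beyond the scatter) and so provides the first reading of a single change in this set. Until now, the compounds differed in more than one place, so nothing could be credited to one group. Here the methoxy on the aromatic carbon, meta to a large group, is tied to a lower number, although the step is modest, and no measurement shown explains it.

From the compounds shown here alone, it remains open whether another group in this same place, such as a hydroxyl, an amine or a fluorine atom, would match the methoxy or go beyond it. Compounds 2 and 3 also differ from compound 1 in more than one place, so the effect of each of their other changes cannot be separated.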